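From Fluoro to Methyl: Compound 3 to Compound 4

This account rests on a few compounds, and the source may have more. Where it says the series, first, only, none or still open, it means among the compounds named here.

In a functional assay on MCF7 cells (Homo sapiens) for antiproliferative activity, read by MTT assay, with a stated time of 72 h (a higher number here means a weaker inhibitor, a lower number a stronger inhibitor), compound 1 (`C=CC/N=C1\S/C(=C\c2ccc(OC)cc2)C(=O)N1C`) gives > 100000 nM as its result, and this is a limit of the assay, not a number. Compound 2 (`COc1ccc(/C=C2\S/C(=N\c3ccc(C(C)(C)C)cc3)N(C)C2=O)cc1`) also gives only a limit, > 100000 nM in this assay again. Among the measured compounds shown here, compound 3 (`COc1ccc(/C=C2\S/C(=N\c3ccc(F)cc3)N(C)C2=O)cc1`) gives 66500 nM as the only actual number of the three.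

Compound 4 (`COc1ccc(/C=C2\S/C(=N\c3ccc(C)cc3)N(C)C2=O)cc1`) carries methyl in place of fluoro on an aromatic carbon, para to a large group (methyl in place of fluoro on an aromatic carbon).

Two measured steps lead to compound 3. The more relevant one changes the group on that aromatic carbon and shows an at least 1.5-fold lower number from compound 2 to compound 3 (0.17 log units; that floor lies within the scatter) as its size. The other changes the group on the double-bonded nitrogen and shows an at least 1.5-fold lower number from compound 1 to compound 3 (0.17 log units; that floor lies within the scatter) as its size. As far as these compounds go, both sizes are only floors because of the limit of > 100000 nM in this assay, at which 2 of the 3 values shown sit, and the true steps remain unknown.

Neither step therefore gives a firm direction for the new change, so no shift beyond the scatter is expected. The expected move is a 1.2-fold higher number from compound 3 to compound 4 (0.08 log units; within the scatter) and it would stay within that scatter. Compound 4 could also be expected to reach the limit of the assay. For compound 4 the estimated value is 80000 nM with an expected range from 40000 nM to 160000 nM in this assay as well.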

Compound 4, half-maximal inhibitory concentration: > 100000 nM
Compound 4: only a limit was reported; the forecaster's own chance of this, stated with the estimate: 35%; middle value at least 1.2-fold (0.09 log units) from the limit.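

Putting methyl where fluoro sat gives an at least 1.5-fold higher number from compound 3 to compound 4 (0.17 log units; that floor lies within the scatter) in this assay, and that floor does not establish a real difference between the two groups. What is new is that a group as small as methyl, and not only the larger tert-butyl of compound 2, leaves the 4-substituted phenyl series without a readable number, so that compound 3 alone keeps one. Even so, compound 3 cannot be called stronger than the others, and the steps from compound 1 and from compound 2 to compound 4 cannot be read, as both ends of each are limits; the true size of the fluoro to methyl step also stays unknown because of the ceiling of the assay: the limit of > 100000 nM in this assay, at which 3 of the 4 values shown sit.

As far as these compounds go, it remains open whether a chloro group, a nitrile or an amine at this same place on the ring would give a readable number in this assay. From the compounds shown here alone, it is also open whether any group here could give a clearly stronger result than compound 3 with its 66500 nM.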